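Chloro on the Aromatic Ring of Compound 1

This account rests on a few compounds, and the source may have more. Where it says the series, first, only, none or still open, it means among the compounds named here.

Compound 1 `CC(C)(C)OC(=O)/C=C1/C(=O)Nc2ccccc21` is measured in a functional assay on MDA-MB-231 cells (Homo sapiens) for inhibition, read by CCK-8 assay, with a stated time of 72 h, tested at 20 uM (a lower number here means less inhibition of growth, a higher number more inhibition of growth at the concentration tested), where compound 1 gives 87.6%. Compound 2 `CC(C)(C)OC(=O)/C=C1/C(=O)N(Cc2ccccc2)c2ccccc21` gives 87.1% in this assay. For the measured compounds named here, the single measured step, a number 0.5 percentage points lower from compound 1 to compound 2 (within the scatter), concerns the amide-type nitrogen in a ring, not an aromatic carbon. Compound 1 stands at the top of the two numbers only nominally, its gap to compound 2 lying within the scatter. Compound 3 `CC(C)(C)OC(=O)/C=C1/C(=O)Nc2c(Cl)cccc21` differs from compound 1 by chloro in place of hydrogen on an aromatic carbon. Going by the values given here, no measured step touches the aromatic ring, so the known step gives no direct guide, and both measured numbers sit close together. Compound 3 is therefore expected to give 85%, between 70% and 95%, a step of a number 2.6 percentage points lower from compound 1 to compound 3 (within the scatter) expected to stay within the scatter.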

Compound 3, percent growth inhibition at one concentration: 87.4%
The estimate for compound 3 lay 2.4 percentage points below the measured number, within the range that was stated.
By their numbers in this assay, from the lowest: compounds 2, 3 and 1 (each within the scatter of the next).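

Chloro in place of hydrogen on an aromatic carbon gives a number 0.2 percentage points lower from compound 1 to compound 3 (within the scatter), the first measured step on the aromatic ring of the shared core. At this one carbon, ortho to a fused ring and meta to a fused ring, a chlorine atom leaves the number in this assay indistinguishable from that of compound 1. No measurement bears on why this step is so small. Still open, on these data alone, is whether an amine or a methoxy group on this carbon would also leave the number within the scatter, and whether chloro on another aromatic carbon would do the same.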